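Swapping the amide aryl group for a dichloropyrimidine

The compounds below may be only part of what the source reports. "The series", "measured", "known", "first", "only" and "open" are said of these compounds alone.

Of the compounds shown here, three sharing one core have been measured in a functional assay on HepG2 cells (Homo sapiens) for antiproliferative activity, read by CCK-8 assay, with a stated time of 72 h; on this read-out higher numbers stand for weaker inhibition and lower numbers for stronger inhibition. Compound 1 `COc1ccc(C(=O)Nc2cccc(-c3oc4cc(-c5ccc(F)cc5)ccc4c(=O)c3O)c2)cc1` gives 8420 nM, compound 2 `COc1ccccc1C(=O)Nc1cccc(-c2oc3cc(-c4ccc(F)cc4)ccc3c(=O)c2O)c1` gives 14500 nM, and compound 3 `O=C(Nc1cccc(-c2oc3cc(-c4ccc(F)cc4)ccc3c(=O)c2O)c1)c1ccc(Br)cc1` gives 13900 nM. Compound 2 holds the highest number of the three, yet a 1.7-fold higher number from compound 1 to compound 2 (0.24 log units; within the scatter) and a 1.0-fold lower number from compound 2 to compound 3 (0.02 log units; within the scatter) are both within the scatter, so the three cannot really be told apart. Compound 4 `O=C(Nc1cccc(-c2oc3cc(-c4ccc(F)cc4)ccc3c(=O)c2O)c1)c1cnc(Cl)nc1Cl` is not yet measured; it differs from compound 2 in one place: 2,4-dichloropyrimidin-5-yl in place of 2-methoxyphenyl on a carbonyl carbon. The earlier changes on a carbonyl carbon, a 1.7-fold higher number from compound 1 to compound 2 (0.24 log units; within the scatter) and a 1.0-fold lower number from compound 2 to compound 3 (0.02 log units; within the scatter), moved the number little. No step beyond the scatter is therefore expected, a 1.2-fold lower number from compound 2 to compound 4 (0.08 log units; within the scatter). Compound 4 is estimated at 12000 nM, with a range from 4500 nM to 32000 nM.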

Compound 4, half-maximal inhibitory concentration: > 100000 nM
Compound 4: no number, only a limit; the forecaster's own chance of this, stated with the estimate: 10%; middle value at least 8.3-fold (0.92 log units) away from the limit.
By their numbers in this assay, from the lowest: compounds 1, 3 and 2 (each within the scatter of the next). At a limit, above all of these: compound 4.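

Among the three substituted phenyl amides, changes on this carbonyl carbon stayed within the scatter, so the position looked forgiving. In this assay, replacing the phenyl ring with 2,4-dichloropyrimidin-5-yl gives steps beyond the scatter (an at least 6.8-fold higher number from compound 2 to compound 4 (0.83 log units; beyond the scatter)) and (an at least 7.1-fold higher number from compound 3 to compound 4 (0.85 log units; beyond the scatter)) and (an at least 11-fold higher number from compound 1 to compound 4 (1.07 log units; beyond the scatter)). Compound 4 has no exact number, only a limit: the limit of > 100000 nM in this assay, at which 1 of the 4 values shown sits.

Going by these compounds, it remains open whether the ring nitrogens or the two chlorines account for this loss, as a plain pyrimidin-5-yl or a 2,4-dichlorophenyl group would help separate them. On these data alone, the effect of an amine in place of either chlorine also remains open.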